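The source may report more compounds than this note shows. Statements on the series, on what has been measured and on what is new or still open speak of the compounds shown alone.

In an ADME assay on MT4 cells (Homo sapiens) for cytotoxicity, read by MTT assay, with a stated time of 5 days (on this read-out lower numbers stand for higher toxicity in this test and higher numbers for lower toxicity in this test), three compounds on a shared core have been measured. Compound 1 `Cc1cc(/C=C/C#N)cc(C)c1Oc1cc(NCCN(C)C)nc(Nc2ccc(C#N)cc2)c1` gives 4270 nM, compound 2 `C=CCNc1cc(Oc2c(C)cc(/C=C/C#N)cc2C)cc(Nc2ccc(C#N)cc2)n1` gives 82100 nM, and compound 3 `COCCNc1cc(Oc2c(C)cc(/C=C/C#N)cc2C)cc(Nc2ccc(C#N)cc2)n1` gives 58200 nM. Compound 3 therefore lies within the scatter of compound 2 and far from compound 1.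

Compound 4 `Cc1cc(/C=C/C#N)cc(C)c1Oc1cc(NCC2CCCO2)nc(Nc2ccc(C#N)cc2)c1` has oxolan-2-yl in place of methoxymethyl on a saturated chain carbon bound to a nitrogen on an aromatic ring. In other words, (2-methoxyethyl)amino becomes ((oxolan-2-yl)methyl)amino.

The two large steps, a 19-fold higher number from compound 1 to compound 2 (1.28 log units; beyond the scatter) and a 14-fold higher number from compound 1 to compound 3 (1.13 log units; beyond the scatter), both remove the dimethylamino group of compound 1. Compound 4 has no such group to lose, so these steps offer little guidance. Going by the values given here, the closest precedent is the exchange at the same place, a 1.4-fold lower number from compound 2 to compound 3 (0.15 log units; within the scatter), which stayed small.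

In this assay, the expected change is therefore none beyond the scatter, and the estimated step is a 1.2-fold lower number from compound 3 to compound 4 (0.08 log units; within the scatter). For compound 4 the estimated value is 48000 nM, with an expected range of 17000 nM to 120000 nM.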

Compound 4, half-maximal cytotoxic concentration: 73600 nM
Beside the measured number, compound 4's estimate is 1.5-fold (0.19 log units) below it; the range from low to high includes it.
By their numbers in this assay, from the lowest: compound 1; then compounds 3, 4 and 2 (each within the scatter of the next).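

In this assay, the ring of oxolan-2-yl, a five-membered non-aromatic ring with one hetero atom, is taken up on this saturated chain carbon with no change beyond the scatter: the result is a 1.3-fold higher number from compound 3 to compound 4 (0.10 log units; within the scatter) and also a 1.1-fold lower number from compound 2 to compound 4 (0.05 log units; within the scatter). A ring at this place therefore sits with the open vinyl and methoxymethyl groups, and the gap to the amine-bearing compound remains, at a 17-fold higher number from compound 1 to compound 4 (1.24 log units; beyond the scatter). No measurement offered here accounts for this level or for the gap.

Compound 1 is the only compound shown with an amine on this chain. From the compounds shown here alone, whether a piperidine ring or a primary amine at this place would also give a number as low as that of compound 1 stays open.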